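Longer Alkyl Arms on the Amine: What to Expect

The compounds below may be only part of what the source reports. "The series", "measured", "known", "first", "only" and "open" are said of these compounds alone.

Among the measured compounds shown here, in a physicochemical assay for lipophilicity, using the shake flask method, measured as octanol-water partition, at pH 7.4 (a higher number here means a more lipophilic compound, a lower number a more polar compound), compound 1 `CN(C)CCCOc1ccc(C(=O)/C=C/c2ccccc2)cc1` gives 1.59, while compound 2 `CCCN(CCC)CCCOc1ccc(C(=O)/C=C/c2ccccc2)cc1` gives 1.91, the higher of the two numbers measured so far. For the measured compounds named here, the single measured step, a number 0.32 log units higher from compound 1 to compound 2 (beyond the scatter), was modest yet beyond the scatter. Compound 3 `CCCCN(CCCC)CCCOc1ccc(C(=O)/C=C/c2ccccc2)cc1` carries the change (dibutylamino in place of dipropylamino on a saturated chain carbon, three bonds along the chain from an oxygen on an aromatic ring), a change of the same kind as the one already measured. Because the earlier step came out as a number 0.32 log units higher from compound 1 to compound 2 (beyond the scatter), a smaller rise in this assay is expected, a number 0.34 log units higher from compound 2 to compound 3 (beyond the scatter). Compound 3 is therefore estimated at 2.25, within a range from 1.9 to 2.6.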

Compound 3, partition coefficient: 2.06
The estimate for compound 3 lay 0.19 log units above the measured number, and the stated range covers the measured number.
By their numbers in this assay, from the lowest: compound 1; then compounds 2 and 3 (each within the scatter of the next).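

In this assay, dibutylamino in place of dipropylamino gives a number 0.15 log units higher from compound 2 to compound 3 (within the scatter), so compound 2 and compound 3 cannot be told apart here, unlike the pair in the earlier step at this position. The wider change, dibutylamino in place of dimethylamino, still gives a number 0.47 log units higher from compound 1 to compound 3 (beyond the scatter), which lies beyond the scatter. Nothing available explains why one step of this kind lies beyond the scatter and the next within it. On these data alone, whether a longer chain on the amine, such as dihexylamino, or a ring amine such as piperidine would give a step beyond the scatter from compound 3 stays open.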